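Butyl to 4-methylphenyl on the shared core of compound 3

A few compounds are considered here, and "the series" means these few. Any claim that something is new, unique, unknown or untested is made for them only; others in the source may bear on it.

For the measured compounds named here, in a functional assay on MIA PaCa-2 cells (Homo sapiens) for antiproliferative activity, read by MTT assay, with a stated time of 48 h (on this read-out lower numbers stand for stronger inhibition and higher numbers for weaker inhibition), compound 3 `CCCCCc1nc(N)n(CC(=O)Nc2ccc(C)cc2)c1-c1ccccc1Br` gives 5600 nM, the lowest of the three numbers so far. Compound 1 `CCCCCc1nc(N)n(CC(=O)Nc2ccccc2)c1-c1ccccc1Br` gives 40600 nM, and compound 2 `Nc1nc(CC2CCCC2)c(-c2ccccc2Br)n1CC(=O)Nc1ccccc1` gives 61400 nM. Of the two measured steps, a 7.3-fold lower number from compound 1 to compound 3 (0.86 log units; beyond the scatter) arose from methyl in place of hydrogen on an aromatic carbon, whereas a 1.5-fold higher number from compound 1 to compound 2 (0.18 log units; within the scatter) arose from cyclopentyl in place of butyl on a saturated chain carbon bound to an aromatic carbon. Compound 4 `Cc1ccc(Cc2nc(N)n(CC(=O)Nc3ccc(C)cc3)c2-c2ccccc2Br)cc1` carries the change (4-methylphenyl in place of butyl on a saturated chain carbon bound to an aromatic carbon). Going by the values given here, only the step from compound 1 to compound 2 touches this position, and it stayed within the scatter, so no step beyond the scatter is expected here. Compound 4 is therefore expected to give about 6000 nM, between 2000 nM and 20000 nM, which is an expected step of a 1.1-fold higher number from compound 3 to compound 4 (0.03 log units; within the scatter).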

Compound 4, half-maximal inhibitory concentration: 2900 nM
For compound 4 the middle estimate is 2.1-fold (0.32 log units) above the measured one; measured number inside the range.
By their numbers in this assay, from the lowest: compounds 4 and 3 (each within the scatter of the next); then compounds 1 and 2 (each within the scatter of the next).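

In this assay the change to 4-methylphenyl gave a 1.9-fold lower number from compound 3 to compound 4 (0.29 log units; within the scatter) and so brought a six-membered aromatic ring to this place with no shift beyond the scatter. The earlier step at this place, a 1.5-fold higher number from compound 1 to compound 2 (0.18 log units; within the scatter) with cyclopentyl in place of butyl, also stayed within the scatter, so neither a saturated ring nor an aromatic ring here has yet separated from butyl. Nothing at hand gives a reason for this result.

Going by these compounds, whether an amine, a carboxylic acid or a longer chain at this place would give a step beyond the scatter remains open.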